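The source may hold more compounds than are shown below. What is called first, only, known or untested is meant among the compounds shown, and "the series" means these compounds.

Working notes on the series. Compound 1 `O=C(CCCCC1CCSS1)NCc1cn(CCCCOc2ccc3ccc(=O)oc3c2)nn1` and compound 2 `COc1ccc(-c2cc3ccc(OCCCCn4cc(CNC(=O)CCCCC5CCSS5)nn4)cc3oc2=O)cc1` share the same core and differ only in one group on an aromatic carbon. In a functional assay on PC-12 cells (Rattus norvegicus) for cytotoxicity, read by MTT assay, with stated times of 3 h and 2 h, tested at 20 uM (a higher number here means a stronger effect of the compound at the concentration tested, a lower number a weaker effect), compound 1 gives 69.8%, while compound 2 gives 52.3% in this assay. The measured step of a number 17.5 percentage points lower from compound 1 to compound 2 (beyond the scatter) is beyond the scatter, and on the two numbers shown compound 2 stands lowest, with compound 1 as its nearest neighbour.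

Compound 3 `O=C(CCCCC1CCSS1)NCc1cn(CCCCOc2ccc3cc(-c4ccc(Cl)c(Cl)c4)c(=O)oc3c2)nn1` has not yet been measured in this assay. Relative to compound 2 the structural change is 3,4-dichlorophenyl in place of 4-methoxyphenyl on an aromatic carbon. Going by the values given here, no measured step exchanges one aryl group for another on that aromatic carbon; the only step at that site, a number 17.5 percentage points lower from compound 1 to compound 2 (beyond the scatter), concerns the entry of an aryl group where hydrogen stood, and so bears on the present change only indirectly. With compound 2 already carrying an aryl group there, the expectation for compound 3 in this assay is a step of no more than the scatter, a number 2.7 percentage points higher from compound 2 to compound 3 (within the scatter), in no firm direction. The estimate for compound 3 in this assay is therefore 55%, with a range from 38% to 72%.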

Compound 3, a percentage reported as activity, at one concentration (the size of the read-out at that concentration, not a potency): 62.9%
Beside the measured number, compound 3's estimate is 7.9 percentage points below it; the measured number falls inside the stated range.
By their numbers in this assay, from the lowest: compound 2; then compounds 3 and 1 (each within the scatter of the next).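

At this aromatic carbon, the identity of the aryl group matters in this assay: the first aryl-for-aryl exchange, 3,4-dichlorophenyl in place of 4-methoxyphenyl, gives a number 10.6 percentage points higher from compound 2 to compound 3 (beyond the scatter) and separates two compounds that both carry an aryl group there. The presence of an aryl group at this position therefore does not by itself produce the step seen with 4-methoxyphenyl, since the entry of 3,4-dichlorophenyl where hydrogen stood gives a number 6.9 percentage points lower from compound 1 to compound 3 (within the scatter) and leaves the two compounds unresolved in this read-out. Nothing available bears on why the two aryl groups give different numbers.

From the compounds shown here alone, whether an unsubstituted phenyl, a 4-chlorophenyl or a non-aromatic group such as an amine or a carboxylic acid at this aromatic carbon would read with compound 2 or with compound 1 remains open. Also open, going by these compounds, is whether the separation between the 4-methoxyphenyl and 3,4-dichlorophenyl compounds persists at a concentration other than the one tested, since each compound is represented here by a single read-out.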